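The compounds below may be only part of what the source reports. "The series", "measured", "known", "first", "only" and "open" are said of these compounds alone.

In a functional assay on A549 cells (Homo sapiens) for antiproliferative activity, read by MTT assay (on this read-out lower numbers stand for stronger inhibition and higher numbers for weaker inhibition), compound 3 `COc1ccc(-c2cc(CN(c3nc4ccc(F)cc4s3)c3nc4ccc(OC)cc4s3)on2)cc1` gives 38800 nM, the highest of the three numbers reported so far, although all three lie within the scatter of one another. Compound 2 `COc1ccc2nc(N(Cc3cc(-c4ccc(OC(F)(F)F)cc4)no3)c3nc4ccc(F)cc4s3)sc2c1` gives 37100 nM, and compound 1 `C#CCN(c1nc2ccc(F)cc2s1)c1nc2ccc(OC)cc2s1` gives 24500 nM. Going by the values given here, the only step that can be judged directly, a 1.0-fold higher number from compound 2 to compound 3 (0.02 log units; within the scatter), shows no change beyond the scatter. Compound 4 `COc1ccc2nc(N(Cc3cc(-c4ccccc4F)no3)c3nc4ccc(F)cc4s3)sc2c1` differs from compound 3 by 2-fluorophenyl in place of 4-methoxyphenyl on an aromatic carbon. Among the compounds with values here, the one step that bears on this change, from compound 2 to compound 3, was flat, and the spread among compounds 1, 2 and 3 is narrow, so nothing points to a step beyond the scatter. Compound 4 is therefore expected to give about 35000 nM, with a range from 15000 nM to 80000 nM. The step expected is a 1.1-fold lower number from compound 3 to compound 4 (0.04 log units; within the scatter), none beyond the scatter.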

Compound 4, half-maximal inhibitory concentration: 51800 nM
Beside the measured number, compound 4's estimate is 1.5-fold (0.17 log units) below it, and the stated range covers the measured number.
By their numbers in this assay, from the lowest: compounds 1, 2, 3 and 4 (each within the scatter of the next, the first and the last beyond it).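

Going by these compounds alone, at this aromatic carbon, next to the ring nitrogen, the earlier compounds showed only a change of the group on the oxygen, whereas here the whole aryl group is exchanged: 2-fluorophenyl in place of 4-methoxyphenyl gives a 1.3-fold higher number from compound 3 to compound 4 (0.13 log units; within the scatter) in this assay and 2-fluorophenyl in place of 4-(trifluoromethoxy)phenyl gives a 1.4-fold higher number from compound 2 to compound 4 (0.14 log units; within the scatter) on the same read-out. Both steps lie within the scatter, so these three aryl groups cannot be told apart here. No evidence is available that bears on this result. As far as these compounds go, it remains open whether an amine or a carboxylic acid on this aryl ring would give a step beyond the scatter. The same holds for a saturated ring such as cyclohexyl in its place.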